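The compounds below may be only part of what the source reports. "The series", "measured", "known", "first", "only" and "open" are said of these compounds alone.

In an ADME assay on HepG2 cells (Homo sapiens) for inhibition, read by resazurin assay, with a stated time of 48 h (on this read-out lower numbers stand for an effect already at smaller amounts and higher numbers for an effect only at larger amounts of compound), two compounds sharing a core have been measured. Compound 1 `O=C(Nc1ccc2sc(-c3ccccc3F)nc2c1)N1CCCC1`, which carries pyrrolidin-1-yl on its carbonyl carbon, gives > 50000 nM, a limit of the assay and not a number. Compound 2 `O=C(Nc1ccc2sc(-c3ccc(F)c(F)c3)nc2c1)N1CCC(F)CC1` gives > 50000 nM, which is likewise only a limit. Compound 2 therefore stands with compound 1 at the limit of > 50000 nM in this assay, at which 2 of the 2 values shown sit. Compound 3 `O=C(Nc1ccc2sc(-c3ccc(F)c(F)c3)nc2c1)N1CCCC1` has pyrrolidin-1-yl in place of 4-fluoropiperidin-1-yl on a carbonyl carbon, a change counted as pyrrolidin-1-yl in place of 4-fluoropiperidin-1-yl on a carbonyl carbon. With compound 2 and compound 1 both at the limit of > 50000 nM in this assay, at which 2 of the 2 values shown sit, no step beyond the scatter is expected in this assay. The expected change is a step that the limit leaves unreadable from compound 2 to compound 3, and the assay will most likely report only a limit again. For compound 3, the estimated value is 60000 nM, with an expected range from 30000 nM to 100000 nM.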

Compound 3, half-maximal effective concentration: > 50000 nM
Compound 3 was reported as a limit; the forecaster's own chance of this, stated with the estimate: 85%; the middle value does not contradict the limit.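

Within the data shown here, compound 1, compound 2 and compound 3 all report only a limit in this assay, so no step among them can be read: the limit of > 50000 nM in this assay, at which 3 of the 3 values shown sit. The compounds shown leave open how large either exchange of groups on the shared core really is.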